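The source may hold more compounds than are shown below. What is called first, only, known or untested is meant among the compounds shown, and "the series" means these compounds.

Compound 1 `Cc1nnc(NC(=O)c2c(O)ccc3cc(-c4cccc(O)c4)ccc23)s1` carries an amide on the shared core, but in an in vitro assay on Sf9 cells for inhibition of 17-beta-hydroxysteroid dehydrogenase type 1 (Homo sapiens), tested at 100 nM (on this read-out higher numbers stand for a stronger effect at the one concentration tested and lower numbers for a weaker effect), compound 1 gives "not determined" (no result reported), so no single number stands for it. Compound 2 `CNC(=O)/C=C/c1c(O)ccc2cc(-c3cccc(O)c3)ccc12` bears a different side chain on the same core, and in this assay compound 2 gives 19%. Compound 3 `O=C(Nc1cccc(O)c1)c1c(O)ccc2cc(-c3cccc(O)c3)ccc12` differs from compound 1 by 3-hydroxyphenyl in place of 5-methyl-1,3,4-thiadiazol-2-yl on an amide-type nitrogen. Among the compounds with values here, without a value for compound 1, no step to compound 3 in this assay can be sized. Compound 3 is therefore expected, on the basis of compound 2 giving 19%, to show roughly 35%, within a range from 5% to 75%.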

Compound 3, a percentage reported as inhibition, at one concentration (the size of the read-out at that concentration, not a potency): 21%
Estimate against measurement, compound 3: 14 percentage points above; the measured number falls inside the stated range.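

Within the data shown here, compound 1 gives "not determined" (no result reported) in this assay, so no step to compound 3 can be read. As far as these compounds go, what exchanging 5-methyl-1,3,4-thiadiazol-2-yl for 3-hydroxyphenyl does to inhibition remains open. No further evidence bears on this result.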